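The compounds below may be only part of what the source reports. "The series", "measured", "known", "first", "only" and "open" are said of these compounds alone.

Measured so far in a functional assay on IMR-90 cells for antagonist activity at B1 bradykinin receptor (Homo sapiens), read by calcium flux; a higher number here means a weaker inhibitor, a lower number a stronger inhibitor:

compound 1 `Cc1nc(-c2c(F)cccc2-c2cnc([C@@H](C)NC(=O)N(C)O)c(F)c2)no1`: 31 nM
compound 2 `CCN(O)C(=O)NCc1ncc(-c2cc(Cl)cc(F)c2-c2nnn(C)n2)cc1F`: 4.6 nM
compound 3 `Cn1nnc(-c2c(F)cc(Cl)cc2-c2cnc(CNC(=O)N(O)C(C)(C)C)c(F)c2)n1`: 1.4 nM

Compound 3 gives the lowest number of the three in this assay. Its nearest neighbour is compound 2, with a 3.3-fold lower number from compound 2 to compound 3 (0.52 log units; beyond the scatter) separating them; compound 1, which carries a different core, gives a number well beyond the scatter above that of compound 3.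

Compound 4 `Cn1nnc(-c2c(F)cc(Cl)cc2-c2cnc(CNC(=O)N(O)C3CCCCC3)c(F)c2)n1` has not yet been measured. It differs from compound 3 in one place: cyclohexyl in place of tert-butyl on an amide-type nitrogen. Among the compounds with values here, the only measured step that bears on this position is a 3.3-fold lower number from compound 2 to compound 3 (0.52 log units; beyond the scatter), where the group on the same amide-type nitrogen grew from ethyl to tert-butyl and the number fell by a modest amount, beyond the scatter. Within the data shown here, compound 4 continues in the direction of a larger group on that nitrogen, though with a ring in place of a branched chain, and no measured pair tells how a ring behaves there. The gain from compound 2 to compound 3 was modest, so a further change of similar size or none beyond the scatter is expected, with the direction uncertain.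

For compound 4 in this assay the estimate is 2 nM, with a range of 0.6 nM to 6 nM; this corresponds to an expected 1.4-fold higher number from compound 3 to compound 4 (0.15 log units; within the scatter).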

Compound 4, half-maximal inhibitory concentration: 3.9 nM
Beside the measured number, compound 4's estimate is 2.0-fold (0.29 log units) below it; the range from low to high includes it.
By their numbers in this assay, from the lowest: compound 3; then compounds 4 and 2 (each within the scatter of the next); then compound 1.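

In this assay the ring does not extend the earlier gain on this amide-type nitrogen: cyclohexyl in place of tert-butyl gives a 2.8-fold higher number from compound 3 to compound 4 (0.44 log units; beyond the scatter) and so reverses part of a 3.3-fold lower number from compound 2 to compound 3 (0.52 log units; beyond the scatter) even though cyclohexyl has more heavy atoms than tert-butyl. Cyclohexyl in place of ethyl gives a 1.2-fold lower number from compound 2 to compound 4 (0.07 log units; within the scatter) so across ethyl, tert-butyl and cyclohexyl the number does not follow the heavy-atom count of the group, and tert-butyl alone stands apart beyond the scatter from both of the others. No measurement shown here explains why tert-butyl gives the lowest number of the three at this position.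

Whether the ring itself or simply the shape of the group accounts for the rise remains open, and cyclopentyl, cyclobutyl or an open chain such as n-hexyl on the same nitrogen would help separate these readings. Also open, from the compounds shown here alone, is whether a branched chain longer than tert-butyl, such as 2-methylbutan-2-yl, or a ring carrying an oxygen, such as tetrahydropyranyl, keeps the number near that of compound 3 at 1.4 nM in this assay on the shared core.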